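The source may report more compounds than this note shows. Statements on the series, on what has been measured and on what is new or still open speak of the compounds shown alone.

In a functional assay on PC-3 cells (Homo sapiens) for antiproliferative activity, read by MTT assay, with a stated time of 48 h (on this read-out lower numbers stand for stronger inhibition and higher numbers for weaker inhibition), compound 1 `O=C(CCCCCC(=O)Nc1nnc(-c2ccncc2)s1)NO` gives > 60000 nM, which is a limit of the assay and not a number. Compound 2 `O=C(CCCCCC(=O)Nc1nnc(-c2cccs2)s1)NO` gives > 60000 nM, which is also a limit. Compound 3 `O=C(CCCCCC(=O)Nc1nnc(-c2cccnc2)s1)NO` has not yet been measured. It carries pyridin-3-yl in place of the thiophen-2-yl of compound 2, on an aromatic carbon of the five-membered aromatic ring: pyridin-3-yl in place of thiophen-2-yl on an aromatic carbon. For the measured compounds named here, the one measured swap at this place is a step that the two limits leave unreadable from compound 1 to compound 2, so it offers no size to carry over. What it does offer is the limit of > 60000 nM in this assay, at which 2 of the 2 values shown sit, shared by a pyridin-4-yl compound and a thiophen-2-yl compound. Little change is therefore expected, and the estimated step is a step that the limit leaves unreadable from compound 2 to compound 3. For compound 3 the estimate is 70000 nM, with an expected range from 25000 nM to 200000 nM.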

Compound 3, half-maximal inhibitory concentration: 54400 nM
Compound 3: middle estimate off by 1.3-fold (0.11 log units), on the high side; measured number inside the range.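

In this assay compound 3 gives 54400 nM, the first true number at this position among the compounds shown. This makes two steps readable, though only as floors: an at least 1.1-fold lower number from compound 2 to compound 3 (0.04 log units; that floor lies within the scatter), and an at least 1.1-fold lower number from compound 1 to compound 3 (0.04 log units; that floor lies within the scatter); neither floor allows pyridin-3-yl to be ranked against thiophen-2-yl or pyridin-4-yl. Changing the aromatic ring at this place has so far produced no separation that the data can resolve, and most of the results remain at a limit of the assay rather than a number: the limit of > 60000 nM in this assay, at which 2 of the 3 values shown sit.

The compounds shown leave open whether an amine or a carboxylic acid on the aromatic ring at this place would give a clearly lower number. They also leave open whether a longer chain elsewhere on the shared core would change the picture.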